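The source may report more compounds than this note shows. Statements on the series, on what has been measured and on what is new or still open speak of the compounds shown alone.

Measured in a functional assay for inhibition, with Rattus norvegicus as the target; a lower number here means a stronger inhibitor, a higher number a weaker inhibitor:
- Compound 1 (`CC(/N=c1\c(O)c(O)\c1=N/c1ccc(C#N)cc1)C(C)(C)C`): 520 nM
- Compound 2 (`C[C@@H](/N=c1\c(O)c(O)\c1=N/c1ccc(C#N)cc1)C(C)(C)C`): 370 nM; 24300 nM (2 entries)
- Compound 3 (`CCC(CC)/N=c1\c(O)c(O)\c1=N/c1ccc(C#N)cc1`): 3340 nM

Among the single numbers, compound 3 stands highest at 3340 nM, and compound 1 lies nearest, with a 6.4-fold higher number from compound 1 to compound 3 (0.81 log units; beyond the scatter). Compound 2 has no single number (the several entries of compound 2 in this assay, 370 nM; 24300 nM (2 entries)), and it also differs from compound 1 in how it is drawn (the fact that one of compounds 1 and 2 is drawn with a defined configuration and the other without, at the place where they differ).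

Compound 4 (`CCC(C)/N=c1\c(O)c(O)\c1=N/c1ccc(C#N)cc1`) differs from compound 3 by hydrogen in place of methyl on a saturated chain carbon, two bonds along the chain from a double-bonded nitrogen, which turns pentan-3-yl into sec-butyl. Only the modest step of a 6.4-fold higher number from compound 1 to compound 3 (0.81 log units; beyond the scatter) bears on this change, and that single step fixes no direction. No step beyond the scatter is therefore expected in this assay, and the estimated step is a 1.1-fold lower number from compound 3 to compound 4 (0.05 log units; within the scatter). Compound 4 is expected at 3000 nM, within an estimated range of 800 nM to 11000 nM.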

Compound 4, half-maximal inhibitory concentration: 2100 nM
For compound 4 the middle estimate is 1.4-fold (0.15 log units) above the measured one, within the range that was stated.
By their numbers in this assay, from the lowest: compound 1; then compounds 4 and 3 (each within the scatter of the next).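

Hydrogen in place of methyl, two bonds along the chain from a double-bonded nitrogen, gives a 1.6-fold lower number from compound 3 to compound 4 (0.20 log units; within the scatter) in this assay, so sec-butyl and pentan-3-yl cannot be told apart here. Ethyl in place of tert-butyl gives a 4.0-fold higher number from compound 1 to compound 4 (0.61 log units; beyond the scatter), a second step beyond the scatter away from the 1,2,2-trimethylpropyl group of compound 1, alongside a 6.4-fold higher number from compound 1 to compound 3 (0.81 log units; beyond the scatter).

From the compounds shown here alone, what a longer chain or a cyclohexyl group would give at this position stays open. Nothing shown accounts for either step.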